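Bromo-to-cyano swap on the amide aryl of compound 1

A few compounds are considered here, and "the series" means these few. Any claim that something is new, unique, unknown or untested is made for them only; others in the source may bear on it.

Among the compounds with values here, compound 1 `O=C(Nc1cccc(-c2oc3cc(-c4ccc(F)cc4)ccc3c(=O)c2O)c1)c1ccc(Br)cc1` stands highest of the three numbers so far in a functional assay on MDA-MB-231 cells (Homo sapiens) for antiproliferative activity, read by CCK-8 assay, with a stated time of 72 h (a higher number here means a weaker inhibitor, a lower number a stronger inhibitor), where compound 1 gives 24900 nM. Compound 2 `COc1cccc(C(=O)Nc2cccc(-c3oc4cc(-c5ccc(F)cc5)ccc4c(=O)c3O)c2)c1` gives 9160 nM in this assay, and compound 3 `Cc1cccc(C(=O)Nc2cccc(-c3oc4cc(-c5ccc(F)cc5)ccc4c(=O)c3O)c2)c1` gives 2840 nM. Both measured steps from compound 1 lower the number: a 2.7-fold lower number from compound 1 to compound 2 (0.43 log units; beyond the scatter) and an 8.8-fold lower number from compound 1 to compound 3 (0.94 log units; beyond the scatter); between the two others, a 3.2-fold lower number from compound 2 to compound 3 (0.51 log units; beyond the scatter).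

Compound 4 `N#Cc1ccc(C(=O)Nc2cccc(-c3oc4cc(-c5ccc(F)cc5)ccc4c(=O)c3O)c2)cc1` differs from compound 1 as follows: cyano in place of bromo on an aromatic carbon. Within the data shown here, no measured step isolates this swap. The steps from compound 1 each exchange 4-bromophenyl for 3-methoxyphenyl or 3-methylphenyl, changing the group and its place at once, whereas compound 4 keeps the place and changes only the group. Those steps show that altering this aryl can shift this assay by a modest amount, but they give no direction for cyano itself.

For compound 4 the expected step is a 1.6-fold lower number from compound 1 to compound 4 (0.19 log units; within the scatter), a small shift not clearly beyond the scatter, with compound 4 estimated at 16000 nM (range 5000 nM to 50000 nM).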

Compound 4, half-maximal inhibitory concentration: 11600 nM
Compound 4: middle estimate off by 1.4-fold (0.14 log units), on the high side; measured number inside the range.
By their numbers in this assay, from the lowest: compound 3; then compounds 2 and 4 (each within the scatter of the next); then compound 1.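

Cyano in place of bromo, on an aromatic carbon para to a large group, gives the first reading of a group change alone on this aryl in this assay (a 2.1-fold lower number from compound 1 to compound 4 (0.33 log units; beyond the scatter)). Within the data shown here, the group at this place therefore moves the number by itself, an effect the earlier steps mixed with a change of place. The number of compound 4 still stands apart from that of compound 3 (a 4.1-fold higher number from compound 3 to compound 4 (0.61 log units; beyond the scatter)), while compound 2 and compound 4 cannot be told apart (a 1.3-fold higher number from compound 2 to compound 4 (0.10 log units; within the scatter)), although 4-cyanophenyl and 3-methoxyphenyl differ in both group and place.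

On these data alone, whether methyl owes the lower number of compound 3 to the group or to its place stays open, as does the reading of an amine or a carboxylic acid at the place held by cyano. No evidence at hand gives a cause for the bromo-to-cyano step.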